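This account rests on a few compounds, and the source may have more. Where it says the series, first, only, none or still open, it means among the compounds named here.

Measured compounds:
Compound 1 `Cc1cc(C)c(CN2CCc3c(Cl)cc([C@@H](CO)[C@@H]4CCOC4)c(Cl)c3C2=O)c(=O)[nH]1`: 2 in a physicochemical assay for lipophilicity, at pH 7.4; a lower number here means a more polar compound, a higher number a more lipophilic compound
Compound 2 `Cc1cc(C)c(CN2CCc3c(Cl)cc([C@@H](C)CO)c(Cl)c3C2=O)c(=O)[nH]1`: 2.5 in this assay
Compound 3 `COc1cc(C)[nH]c(=O)c1CN1CCc2c(Cl)cc([C@H](O)C3COC3)c(Cl)c2C1=O`: 1.4 in this assay

Compound 2 holds the highest of the three numbers. Its nearest neighbour is compound 1, which sits a number 0.50 log units higher from compound 1 to compound 2 (beyond the scatter) when the two are read in the direction from compound 1 to compound 2. Among the compounds with values here, compound 3 lies furthest away, its number being lower than that of compound 2 by more than the usual scatter; compound 3 differs from compound 2 in more than one place, so no single step is drawn between them.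

Compound 4 `Cc1cc(C)c(CN2CCc3c(Cl)cc([C@H](CO)[C@H]4CCCO4)c(Cl)c3C2=O)c(=O)[nH]1` is not yet measured. It arises from compound 2 by one change: oxolan-2-yl in place of methyl on a saturated chain carbon bound to an aromatic carbon and a saturated chain carbon.

Within the data shown here, the step that bears on this is the one from compound 1 to compound 2, which went a number 0.50 log units higher from compound 1 to compound 2 (beyond the scatter) when a four-atom group took the place of an eight-atom group carrying a five-membered ring with one oxygen. The change from compound 2 to compound 4 runs the other way, bringing a five-membered ring with one oxygen back onto the same saturated chain carbon, and compound 1 and compound 4 carry rings of the same size and atom count. Compound 4 is therefore expected to show a number 0.50 log units lower from compound 2 to compound 4 (beyond the scatter). For compound 4 the estimated value is 2, with a range from 1.6 to 2.4.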

Compound 4, distribution coefficient: 2.1
Estimate against measurement, compound 4: 0.10 log units below; the range from low to high includes it.
By their numbers in this assay, from the lowest: compound 3; then compounds 1 and 4 (each within the scatter of the next); then compound 2.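

Oxolan-2-yl in place of methyl on a saturated chain carbon bound to an aromatic carbon and a saturated chain carbon gives, in this assay, a number 0.40 log units lower from compound 2 to compound 4 (beyond the scatter), so a change at this one carbon now has a measured step of its own, whereas the earlier step exchanged a whole group on an aromatic carbon. The two ring-bearing groups, which have the same heavy atoms and the same ring count, are not separated in this read-out, with a number 0.10 log units higher from compound 1 to compound 4 (within the scatter), so for this pair the way the ring is attached leaves no difference beyond the scatter. Nothing measured here explains either step.

Going by these compounds, whether an open chain such as methoxyethyl, or a ring carrying an amine such as pyrrolidin-2-yl, would give a similar step in place of methyl on this carbon remains open. The weight of the defined stereocentre of oxolan-2-yl is also unresolved, as compound 4 shows only one form of it.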